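The source may hold more compounds than are shown below. What is called first, only, known or untested is meant among the compounds shown, and "the series" means these compounds.

In an ADME assay on microsomes from liver (Mus musculus, strain NMRI) for metabolic stability, tested at 2.5 uM (a lower number here means slower removal, a higher number faster removal of the compound), compound 1 `Fc1cc(Cl)ccc1-c1ccc(Cn2nnc3c(C(F)(F)F)cccc32)cn1` gives 0.1 mL/min/g. Compound 2 `Fc1cc(Cl)ccc1-c1ccc(Cn2nnc3c(Br)cccc32)cn1` differs from compound 1 by bromo in place of trifluoromethyl on an aromatic carbon and in this assay compound 2 gives 3.8 mL/min/g, so that there is a 38-fold higher number from compound 1 to compound 2 (1.58 log units; beyond the scatter). Compound 3 `FC(F)(F)c1cc(Br)c2nnn(CC3CC3)c2c1` is built on another core; in this assay compound 3 gives 7.7 mL/min/g, the highest of the three numbers, a value that stands well apart from compound 2 and far from compound 1. The difference between the core of compound 3 and the core of compound 1 is not broken down here.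

Compound 4 `Brc1cc(Br)c2nnn(CC3CC3)c2c1` is compound 3 with the change (bromo in place of trifluoromethyl on an aromatic carbon). Among the measured compounds shown here, this is the same kind of change as the one from compound 1 to compound 2, not the same: in compound 4 the place is meta to a bromo group, meta to a fused ring and para to a fused ring, whereas in compound 2 it is ortho to a fused ring and meta to a fused ring. For the measured compounds named here, the one measured pair shows a large rise, so a rise is expected for compound 4 as well, but with compound 3 already the highest number and the place not identical, a more moderate step is assumed. The step from compound 3 to compound 4 is expected to be a 2.9-fold higher number from compound 3 to compound 4 (0.46 log units; beyond the scatter) in this assay. In this assay compound 4 is estimated at 22 mL/min/g, with the likely range running from 7 mL/min/g to 90 mL/min/g.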

Compound 4, intrinsic clearance in a liver preparation (reported as CLH), per the amount of preparation that the assay uses: 15.3 mL/min/g
The estimate for compound 4 lay 1.4-fold (0.16 log units) above the measured number, and the stated range covers the measured number.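

In this assay, bromo in place of trifluoromethyl on an aromatic carbon does not carry over from one core to the other with the same size of step: the same change on two cores in this assay, a 38-fold higher number (1.58 log units; beyond the scatter) from compound 1 to compound 2 and a 2.0-fold higher number (0.30 log units; within the scatter) from compound 3 to compound 4, 19-fold (1.28 log units) apart, beyond the scatter of two such steps. The large step on the first core, a 38-fold higher number from compound 1 to compound 2 (1.58 log units; beyond the scatter), therefore cannot be taken as a fixed increment for this change, since the step on the second core, a 2.0-fold higher number from compound 3 to compound 4 (0.30 log units; within the scatter), stays within the usual scatter and gives no firm sign of any effect there. This does not show what sets the gap, as the two pairs differ in the core and also in the place of the change, and two pairs cannot separate these or give a rule for further cores in the series.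

Open, from the compounds shown here alone, is whether a nitrile or a methoxy group in the place of the trifluoromethyl would follow the steep course seen on the core of compound 1 or the flat one seen on the core of compound 3. Also open, going by these compounds, is whether a longer chain or an amine on the core of compound 3 would make that core respond to the change as the core of compound 1 does.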